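The source may report more compounds than this note shows. Statements on the series, on what has been measured and on what is new or still open speak of the compounds shown alone.

In an assay on cells for inhibition of histone deacetylase 8 (Homo sapiens), read by fluorescence, with a stated time of 30 min (a lower number here means a stronger inhibitor, a higher number a weaker inhibitor), compound 1 `O=C1NC(=O)/C(=C\c2ccc(OCC(=O)N3N=C(c4ccccc4)CC3c3ccc(F)cc3)cc2)S1` gives 26000 nM. Its two companions sit within the scatter of that figure: compound 2 `O=C1NC(=O)/C(=C\c2ccc(OCC(=O)N3N=C(c4ccccc4)CC3c3ccc(F)cc3F)cc2)S1` gives 34000 nM, and compound 3 `O=C1NC(=O)/C(=C\c2ccc(OCC(=O)N3N=C(c4ccccc4)CC3c3ccc(Br)cc3)cc2)S1` gives 35000 nM, so compound 1 is not separable from either on the numbers shown. The steps among the three are all slight: a 1.3-fold higher number from compound 1 to compound 2 (0.12 log units; within the scatter), a 1.3-fold higher number from compound 1 to compound 3 (0.13 log units; within the scatter), and a 1.0-fold higher number from compound 2 to compound 3 (0.01 log units; within the scatter). Each of these steps alters the aryl group on the saturated ring carbon of the shared core, and none carries the number outside the scatter.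

Compound 4 `O=C1NC(=O)/C(=C\c2ccc(OCC(=O)N3N=C(c4ccc(F)cc4F)CC3c3ccc(F)cc3)cc2)S1` has not yet been measured. It differs from compound 1 by 2,4-difluorophenyl in place of phenyl on a carbon with a double bond to nitrogen. Going by the values given here, no measured step touches that position; the only guidance is that halogen variation on the other aryl ring, in the steps already given, left the numbers essentially flat. On that basis alone a step of a 1.2-fold higher number from compound 1 to compound 4 (0.06 log units; within the scatter) is expected, that is, no change beyond the scatter in either direction. Compound 4 is accordingly estimated at 30000 nM, with a range from 12000 nM to 75000 nM, the width reflecting how little the recorded steps say about this part of the molecule.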

Compound 4, half-maximal inhibitory concentration: > 50000 nM
Compound 4 was reported as a limit (the forecaster's own chance of this, stated with the estimate: 10%); middle value at least 1.6-fold (0.22 log units) away from the limit.
By their numbers in this assay, from the lowest: compounds 1, 2 and 3 (each within the scatter of the next). At a limit, above all of these: compound 4.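

In this assay, compound 4 is recorded only as a limit, > 50000 nM. Placing 2,4-difluorophenyl in place of phenyl gives an at least 1.9-fold higher number from compound 1 to compound 4 (0.28 log units; that floor lies within the scatter), so this first change at the carbon with a double bond to nitrogen, a position that compounds 1, 2 and 3 all hold constant, yields only a floor, and its true size could lie within the scatter or beyond it. The result does exclude a lower number for compound 4 than for compound 1, which the halogen changes on the other aryl ring could not have shown for this position, yet the reading remains a bound and not a figure: the limit of > 50000 nM in this assay, at which 1 of the 4 values shown sits.

The compounds shown leave open how large this step really is, and whether the loss of a measurable value comes from one fluoro substituent or needs both, since no singly substituted ring stands at this position. They also leave open what a methoxy group, an amine or a carboxylic acid on this phenyl ring would do to the number in this assay.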